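The compounds below may be only part of what the source reports. "The series", "measured", "known", "first", "only" and "open" are said of these compounds alone.

Measured in an assay on isolated protein (Mus musculus) for inhibition of IL15-IL15 receptor (Homo sapiens), read by resazurin assay, with stated times of 30 min and 2.5 days; on this read-out lower numbers stand for stronger inhibition and higher numbers for weaker inhibition:
compound 1 `CCCCCCCCCCSc1nnc(Cc2nn(C)c(=O)c3ccccc23)n1C`: 7600 nM
compound 2 `Cn1c(Cc2nn(C)c(=O)c3ccccc23)nnc1SCC(=O)Nc1ccc(O)cc1`: "not active" (no number reported)
compound 3 `Cn1c(Cc2nn(C)c(=O)c3ccccc23)nnc1SCCCCCCCC(=O)Nc1ccc(O)cc1`: > 30000 nM

The value shown for compound 3 is a limit of this assay, not a number; (the limit of > 30000 nM in this assay, at which 1 of the 3 values shown sits). Compound 2 carries no number at all in this assay and is reported only as inactive, so it can be placed against compound 1 only in the sense that compound 1 does return a number, 7600 nM, and compound 2 does not.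

Compound 4 `Cn1c(Cc2nn(C)c(=O)c3ccccc23)nnc1SCC(=O)Nc1ccc(Br)cc1Br` differs from compound 2 by 2,4-dibromophenyl in place of 4-hydroxyphenyl on an amide-type nitrogen. Among the compounds with values here, the one measured step, an at least 3.9-fold higher number from compound 1 to compound 3 (0.59 log units; beyond the scatter), concerns the end of the long chain and not the group on the amide nitrogen, so no measured step bears on the change from compound 2 to compound 4. The anchor is the inactivity of compound 2 together with the high number of compound 1. Nothing in the data points to a direction for this change, so no step beyond the scatter is assumed either way, and it remains likely that compound 4 also returns only a limit. Compound 4 is estimated at 25000 nM, with a range of 6000 nM to 80000 nM, in this assay.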

Compound 4, half-maximal inhibitory concentration: > 30000 nM
Compound 4 gave a limit, no number; the forecaster's own chance of this, stated with the estimate: 55%; middle value at least 1.2-fold (0.07 log units) from the limit.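

In this assay compound 4 gives > 30000 nM, a limit and not a number. Against compound 2, which carries no number, no step can be read, and the result joins a shared limit: the limit of > 30000 nM in this assay, at which 2 of the 4 values shown sit.

The compounds shown leave open whether any group on the amide-type nitrogen returns a number in this assay.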